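Aryl swap on the triazole: compound 3 to compound 4

A few compounds are considered here, and "the series" means these few. Any claim that something is new, unique, unknown or untested is made for them only; others in the source may bear on it.

- compound 1 `COc1ccc([C@@H]2C/C(=N/OCc3cn(-c4ccc(O)cc4)nn3)c3cc(CC=C(C)C)c(OC)cc3O2)cc1`: 65%
- compound 2 `COc1ccc([C@@H]2C/C(=N/OCc3cn(-c4ccc(C#N)cc4)nn3)c3cc(CC=C(C)C)c(OC)cc3O2)cc1`: 50%
- compound 3 `COc1ccc([C@@H]2C/C(=N/OCc3cn(-c4ccc(Cl)cc4C)nn3)c3cc(CC=C(C)C)c(OC)cc3O2)cc1`: 20%

In a functional assay on HCT-116 cells (Homo sapiens) for inhibition, read by sulforhodamine B assay, with a stated time of 48 h, tested at 50 uM (on this read-out lower numbers stand for less inhibition of growth and higher numbers for more inhibition of growth at the one concentration tested), compound 3 stands lowest of the three. Compound 4 `COc1ccc([C@@H]2C/C(=N/OCc3cn(-c4cccc(CO)c4)nn3)c3cc(CC=C(C)C)c(OC)cc3O2)cc1` differs from it by 3-(hydroxymethyl)phenyl in place of 4-chloro-2-methylphenyl on an aromatic nitrogen, with 3-(hydroxymethyl)phenyl in place of 4-chloro-2-methylphenyl on an aromatic nitrogen. Among the measured compounds shown here, two measured steps bear on this change, a number 45 percentage points lower from compound 1 to compound 3 (beyond the scatter) and a number 30 percentage points lower from compound 2 to compound 3 (beyond the scatter), one large and one modest, and both end on the 4-chloro-2-methylphenyl group. For the measured compounds named here, no measured compound carries 3-(hydroxymethyl)phenyl, so the size remains uncertain. A modest upward step is therefore expected in this assay. The expected change is a number 25 percentage points higher from compound 3 to compound 4 (beyond the scatter). For compound 4 the estimated value is 45%, with an expected range from 25% to 65%.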

Compound 4, percent growth inhibition at one concentration: 27%
The estimate for compound 4 lay 18 percentage points above the measured number; low and high end bracket the measured number.
By their numbers in this assay, from the lowest: compounds 3 and 4 (each within the scatter of the next); then compound 2; then compound 1.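

In this assay, 3-(hydroxymethyl)phenyl on the aromatic nitrogen does not reach the level of the 4-hydroxyphenyl or 4-cyanophenyl compounds, with a number 38 percentage points lower from compound 1 to compound 4 (beyond the scatter) and a number 23 percentage points lower from compound 2 to compound 4 (beyond the scatter), while a number 7 percentage points higher from compound 3 to compound 4 (within the scatter) leaves it level with the 4-chloro-2-methylphenyl compound. A hydroxyl on the aryl substituent is therefore not enough by itself, as compound 1 and compound 4 both carry one. Nothing available here gives a cause for these steps.

The compounds shown leave open whether a 4-(hydroxymethyl)phenyl or 3-hydroxyphenyl group would stand with compound 1 or with compound 4. On these data alone, how an amine or a carboxylic acid on the aryl ring would read also stays open.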